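The compounds below may be only part of what the source reports. "The series", "measured", "known", "first", "only" and "open" are said of these compounds alone.

Working notes on the series. Compound 1 `Oc1ccc(CCCC[C@H](O)CCc2ccc(O)cc2)cc1` in a functional assay on RAW264.7 cells (Mus musculus) for inhibition, read by Griess assay, with a stated time of 18 h (on this read-out higher numbers stand for weaker inhibition and lower numbers for stronger inhibition), gives > 25000 nM, which is a limit of the assay and not a number. Compound 2 `O=C(CCCCc1ccc(O)c(O)c1)CCc1ccc(O)c(O)c1` in this assay gives 16800 nM, the only number shown. The other value shown, that of compound 1, is a limit (the limit of > 25000 nM in this assay, at which 1 of the 2 values shown sits). Compound 3 `O=C(CCCCc1ccc(O)cc1)CCc1ccc(O)c(O)c1` has not yet been measured. It differs from compound 2 by hydrogen in place of hydroxy on an aromatic carbon. Within the data shown here, no step between measured compounds covers this change, so the expectation rests on compound 2 and on compound 1. The expected step of a 1.5-fold higher number from compound 2 to compound 3 (0.17 log units; within the scatter) is toward weaker inhibition, beyond the scatter. Compound 3 is estimated at 25000 nM, within 10000 nM to 60000 nM, with a fair chance that only a limit is reported.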

Compound 3, half-maximal inhibitory concentration: 13200 nM
For compound 3 the middle estimate is 1.9-fold (0.28 log units) above the measured one; the range from low to high includes it.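

In this assay hydrogen in place of this hydroxy, turning 3,4-dihydroxyphenyl into 4-hydroxyphenyl, gives a 1.3-fold lower number from compound 2 to compound 3 (0.10 log units; within the scatter) as the first step read at this place. This hydroxy, ortho to a hydroxy group, thus makes no difference beyond the scatter on this read-out, and compound 3 still gives a number and not a limit. No measurement shown speaks to a cause of this. Open, going by these compounds, is whether the remaining hydroxy on that ring can also be replaced, and whether a methoxy or an amine at this place would read the same. Also open, on these data alone, is how the carbonyl or a longer chain bears on the value.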